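The compounds below may be only part of what the source reports. "The series", "measured", "known", "first", "only" and "open" are said of these compounds alone.

Measured so far in an ADME assay on microsomes from liver (Homo sapiens) for metabolic stability, read by LC-MS, using NADPH, tested at 5 uM; on this read-out higher numbers stand for a longer-lived compound and lower numbers for a shorter-lived compound:
- compound 1 `[N-]=[N+]=NCc1nnc(-c2cc(S(N)(=O)=O)c(SCc3ccccc3)cc2Cl)o1`: > 1 h
- compound 2 `NC(=O)c1cn(Cc2nnc(-c3cc(S(N)(=O)=O)c(SCc4ccccc4)cc3Cl)o2)nn1`: 0.435 h

The value of compound 1 is a limit of the assay, not a number. Among the measured compounds shown here, compound 2 therefore holds the only number in this set, the other entry being a limit (the limit of > 1 h in this assay, at which 1 of the 2 values shown sits). For the measured compounds named here, the single measured step, an at least 2.2-fold lower number from compound 1 to compound 2 (0.36 log units; beyond the scatter), concerns the exchange of the azido group for the triazole and does not touch the group carried by the triazole itself.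

Compound 3 `CC(C)(O)c1cn(Cc2nnc(-c3cc(S(N)(=O)=O)c(SCc4ccccc4)cc3Cl)o2)nn1` differs from compound 2 by 1-hydroxy-1-methylethyl in place of carbamoyl on an aromatic carbon. Going by the values given here, no measured step covers a change of this kind, so there is nothing to point to a shift in either direction beyond the scatter. Compound 3 is therefore expected to sit close to compound 2, giving a step of a 1.1-fold higher number from compound 2 to compound 3 (0.06 log units; within the scatter). Compound 3 is estimated at 0.5 h, within 0.22 h to 1.1 h.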

Compound 3, half-life: 0.23 h
For compound 3 the middle estimate is 2.2-fold (0.34 log units) above the measured one; the measured number falls inside the stated range.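

In this assay, among the compounds shown here, the first exchange on this aromatic carbon of the triazole, 1-hydroxy-1-methylethyl in place of carbamoyl, gives a 1.9-fold lower number from compound 2 to compound 3 (0.28 log units; within the scatter), so the two groups cannot be told apart on this read-out. With a second triazole now measured, replacing azido gives an at least 4.3-fold lower number from compound 1 to compound 3 (0.63 log units; beyond the scatter), and the earlier drop is thus seen with both groups on the triazole, neither compound going against it. The size of this step remains only a bound, as its starting point is a limit of the assay held by compound 1: the limit of > 1 h in this assay, at which 1 of the 3 values shown sits.

Going by these compounds, whether an amine, a carboxylic acid, a methyl or a longer chain on this aromatic carbon would shift the half-life beyond the scatter stays open. On these data alone, how far compound 1 actually lies from the two triazoles also remains unknown.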